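A Fluoro Substituent on the Phenyl of Compound 2

The compounds below may be only part of what the source reports. "The series", "measured", "known", "first", "only" and "open" are said of these compounds alone.

Measured compounds:
compound 1, `CN(C)CCn1cnnc1-c1cc(Oc2ccc(NC(=O)N/N=C/c3c[nH]c4ccccc34)cc2F)ccn1` — in a functional assay on U-87MG ATCC cells (Homo sapiens) for cytotoxicity, read by MTT assay, with a stated time of 72 h (a higher number here means a weaker inhibitor, a lower number a stronger inhibitor), compound 1 gives 690 nM
compound 2, `CN(C)CCn1cnnc1-c1cc(Oc2ccc(NC(=O)N/N=C/c3ccccc3)cc2F)ccn1` — in this assay compound 2 gives 2250 nM

Within the data shown here, compound 2 holds the highest of the two numbers; its nearest neighbour is compound 1, separated by the one measured step, a 3.3-fold higher number from compound 1 to compound 2 (0.51 log units; beyond the scatter). Compound 3, `CN(C)CCn1cnnc1-c1cc(Oc2ccc(NC(=O)N/N=C/c3ccc(F)cc3)cc2F)ccn1`, differs from compound 2 by fluoro in place of hydrogen on an aromatic carbon. Among the measured compounds shown here, no measured step concerns a substituent entering the phenyl; the only step exchanges the whole ring. Compound 3 is therefore expected to stay close to compound 2, with a 1.1-fold lower number from compound 2 to compound 3 (0.05 log units; within the scatter) not beyond the scatter. Compound 3 is estimated at 2000 nM, within 900 nM to 4500 nM.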

Compound 3, half-maximal inhibitory concentration: 2310 nM
For compound 3 the middle estimate is 1.2-fold (0.06 log units) below the measured one; the measured number falls inside the stated range.
By their numbers in this assay, from the lowest: compound 1; then compounds 2 and 3 (each within the scatter of the next).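

In this assay, fluoro on the phenyl, para to a large group, leaves the number effectively unchanged (a 1.0-fold higher number from compound 2 to compound 3 (0.01 log units; within the scatter)), so this substitution at this position gives no measurable change. With the 4-fluorophenyl in place, the gap to the 1H-indol-3-yl compound remains (a 3.3-fold higher number from compound 1 to compound 3 (0.52 log units; beyond the scatter)), and it is about as large as the one seen with the unsubstituted phenyl. No independent measurement bearing on this result is available. The compounds shown leave open whether an amine or a carboxylic acid in place of the fluoro would shift the number. They also leave open whether a methoxy group there would narrow the gap to compound 1.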